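Moving the Bromine: Cytotoxicity Outlook for Compound 4

The source may hold more compounds than are shown below. What is called first, only, known or untested is meant among the compounds shown, and "the series" means these compounds.

Compound 1, `CCOC(=O)/C(C#N)=C/c1cc(C)n(-c2cccc(-c3nnn[nH]3)c2)c1C`: 76800 nM
Compound 2, `CCOC(=O)C(=Cc1cc(C)n(-c2cccc(-c3nnn[nH]3)c2)c1C)C(=O)OCC`: 77400 nM
Compound 3, `Cc1cc(/C=C2\SC(=S)N(c3cccc(Br)c3)C2=O)c(C)n1-c1cccc(-c2nnn[nH]2)c1`: 22600 nM

All three compounds were tested in an ADME assay on MT2 cells (Homo sapiens) for cytotoxicity, read by XTT assay, with a stated time of 4 days; a higher number here means that more compound is tolerated, a lower number that less compound is tolerated. Compound 3 stands lowest of the three; compound 1 and compound 2 both give higher numbers, and both gaps lie beyond the usual scatter, so compound 3 is the least tolerated of the measured set.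

Compound 4, `Cc1cc(/C=C2\SC(=S)N(c3ccc(Br)cc3)C2=O)c(C)n1-c1cccc(-c2nnn[nH]2)c1`, has not yet been measured in this assay. It differs from compound 3 in one place: 4-bromophenyl in place of 3-bromophenyl on an amide-type nitrogen in a ring The two have the same atoms, joined differently, and the change sits on an amide-type nitrogen in a ring of a five-membered non-aromatic ring with one nitrogen and one sulfur. Among the measured compounds shown here, no measured pair shows a change of this kind, so nothing here fixes the size of the step. The expected step from compound 3 to compound 4 is small, staying within the scatter, a 1.0-fold lower number from compound 3 to compound 4 (0.01 log units; within the scatter). Compound 4 is therefore expected to give about 22000 nM, between 8000 nM and 60000 nM.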

Compound 4, half-maximal cytotoxic concentration: 46800 nM
The estimate for compound 4 lay 2.1-fold (0.33 log units) below the measured number; measured number inside the range.
By their numbers in this assay, from the lowest: compound 3; then compounds 4, 1 and 2 (each within the scatter of the next).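

Moving the bromine alone gives a 2.1-fold higher number from compound 3 to compound 4 (0.32 log units; beyond the scatter) in this assay and so shows that the place of the bromine on this phenyl group can change how much compound the cells tolerate, even though the atoms stay the same. The earlier compounds shown here offered no pair that isolated such a change. Nothing available here explains the shift.

The compounds shown leave open whether putting chlorine, an amine or a carboxylic acid in place of the bromine would shift the number further. They also leave open how a phenyl group with no bromine would behave.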